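A few compounds are considered here, and "the series" means these few. Any claim that something is new, unique, unknown or untested is made for them only; others in the source may bear on it.

Compound 1 `Cn1cc(/C=C/C(=O)c2ccccc2)cc1/C=C/C(=O)NO` is the reference point of this small set. In an assay on isolated protein for inhibition of histone deacetylase HD1B (Zea mays) (on this read-out higher numbers stand for weaker inhibition and lower numbers for stronger inhibition), compound 1 gives 260 nM, the lowest of the three numbers recorded; the nearest is compound 3 `COc1cccc(C(=O)/C=C/c2cc(/C=C/C(=O)NO)n(C)c2)c1`, which in this assay gives 600 nM, and the furthest is compound 2 `Cn1cc(/C=C/C(=O)c2ccccc2F)cc1/C=C/C(=O)NO`, which in this assay gives 3400 nM.

Compound 4 `Cn1cc(/C=C/C(=O)c2ccc(-c3ccccc3)cc2)cc1/C=C/C(=O)NO` differs from compound 1 by a single change: phenyl in place of hydrogen on an aromatic carbon. Among the measured compounds shown here, no measured step introduces a phenyl group, so the closest guides are the two other substitutions on the same aromatic carbon ring of compound 1. The fluoro substitution gave a 13-fold higher number from compound 1 to compound 2 (1.12 log units; beyond the scatter), and the methoxy substitution gave a 2.3-fold higher number from compound 1 to compound 3 (0.36 log units; beyond the scatter). Both additions to that ring raised the number, one modestly and one strongly, and nothing in the set points the other way.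

On that basis compound 4 is expected to show a modest step in this assay toward a higher number, of the order seen with the methoxy group rather than with the fluoro group, giving an expected 2.3-fold higher number from compound 1 to compound 4 (0.36 log units; beyond the scatter). The estimate for compound 4 in this assay is therefore 600 nM, with a plausible range from 200 nM to 2000 nM.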

Compound 4, half-maximal inhibitory concentration: 31800 nM
The estimate for compound 4 lay 53-fold (1.72 log units) below the measured number, outside the stated range (above it).
By their numbers in this assay, from the lowest: compound 1; then compound 3; then compound 2; then compound 4.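

In this assay, phenyl on an aromatic carbon para to a large group gives a 120-fold higher number from compound 1 to compound 4 (2.09 log units; beyond the scatter) and so goes well past both a 13-fold higher number from compound 1 to compound 2 (1.12 log units; beyond the scatter) and a 2.3-fold higher number from compound 1 to compound 3 (0.36 log units; beyond the scatter) in size. Among the compounds shown here, the earlier compounds showed that additions to this ring raise the number by very different amounts, but only this step shows how far the number can climb, and it places compound 4 highest of the four. Nothing available here accounts for the size of this step.

With a single group at this carbon, the compounds shown leave open whether the large rise belongs to the aromatic ring itself or would also appear with a smaller group such as methyl or chlorine, or with a saturated cyclohexyl ring. They also leave open whether an amine or a carboxylic acid on the outer phenyl ring would bring the number back toward that of compound 1, or whether a longer chain in place of the phenyl would behave any differently.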